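Ring amine in place of dimethylamino on the chain

The source may hold more compounds than are shown below. What is called first, only, known or untested is meant among the compounds shown, and "the series" means these compounds.

Compounds measured so far:
Compound 1, `CCc1c(O)c(=O)ccn1CCN(C)C`: 9.66
Compound 2, `Cc1c(O)c(=O)ccn1CCN(C)C`: 9.75
Compound 3, `O=c1cc(CN2CCCCC2)n(CCN2CCCCC2)cc1O`: 8.83

In a physicochemical assay for acid dissociation, using potentiometric titration, compound 1 gives 9.66, the second highest of the three numbers. Its nearest neighbour is compound 2, which gives 9.75; the step of a number 0.09 log units higher from compound 1 to compound 2 (within the scatter) is within the scatter, so the two cannot be ordered. The furthest is compound 3, which gives 8.83, a number beyond the scatter below compound 1.

Compound 4, `CCc1c(O)c(=O)ccn1CCN1CCCCC1`, has not yet been measured. It differs from compound 1 in one place: piperidin-1-yl in place of dimethylamino on a saturated chain carbon, two bonds along the chain from an aromatic nitrogen.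

Among the compounds with values here, the only measured step, from compound 1 to compound 2, swaps hydrogen for methyl on the core and does not touch the chain amine. Within the data shown here, compound 3 carries piperidin-1-yl on the chain but also a second piperidinylmethyl group on the core, so no single step separates it from compound 1. Among the measured compounds shown here, the data thus hold no step that bears directly on this change, and the expectation in this assay for compound 4 is a step of a number 0.06 log units lower from compound 1 to compound 4 (within the scatter), that is, nothing beyond the scatter. Compound 4 is therefore estimated at 9.6, within the range 9.1 to 10.1.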

Compound 4, acid dissociation constant: 9.67
Beside the measured number, compound 4's estimate is 0.07 log units below it; measured number inside the range.
By their numbers in this assay, from the lowest: compound 3; then compounds 1, 4 and 2 (each within the scatter of the next).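

In this assay, exchanging dimethylamino for piperidin-1-yl on the saturated chain carbon gives a number 0.01 log units higher from compound 1 to compound 4 (within the scatter), so the two compounds cannot be ordered. Within the data shown here, compound 3 also carries piperidin-1-yl on the chain but differs from compound 1 in more than one place, so this is the first step to isolate the change, and a six-membered non-aromatic ring at this place leaves the number within the scatter. Nothing measured alongside these compounds bears on why this is so.

The compounds shown leave open whether a morpholine ring, a pyrrolidine ring or a primary amine at this place would also stay within the scatter. They also leave open whether a longer chain between the aromatic nitrogen and the piperidin-1-yl group would do the same.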